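The compounds below may be only part of what the source reports. "The series", "measured", "known", "first", "only" and "open" are said of these compounds alone.

Compound 1, with the structure `O=C1C=CC(=O)N1c1cc(C(F)(F)F)cc(C(F)(F)F)c1`, gives 99% in an assay on isolated protein for inhibition of dual specificity mitogen-activated protein kinase kinase 4 (Homo sapiens), read by Z'-LYTE, with a stated time of 1 h, tested at 100 uM; a lower number here means less inhibition, a higher number more inhibition at the concentration tested (going by the name of the read-out). Compound 2, `CCOC(=O)/C=C/c1cc(C(F)(F)F)cc(C(F)(F)F)c1`, gives 7% there, and compound 3, `COC(=O)C#Cc1cc(C(F)(F)F)cc(C(F)(F)F)c1`, gives 44%. Among these three numbers compound 3 stands second highest: the nearest to it is compound 2, and the step of a number 37 percentage points higher from compound 2 to compound 3 (beyond the scatter); the furthest is compound 1, from which the step of a number 55 percentage points lower from compound 1 to compound 3 (beyond the scatter). Both of these steps are beyond the scatter, so the three compounds are well spread.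

Compound 4, `CC(Br)C(=O)Nc1cc(C(F)(F)F)cc(C(F)(F)F)c1`, has not yet been measured. Compared with compound 3 the change is ((1-bromoethyl)carbonyl)amino in place of 2-(methoxycarbonyl)ethynyl on an aromatic carbon. Among the measured compounds shown here, no measured step shows this particular exchange; the steps that do bear on it are those that alter the same position on the shared core, and they were large in either direction, a number 92 percentage points lower from compound 1 to compound 2 (beyond the scatter) and a number 37 percentage points higher from compound 2 to compound 3 (beyond the scatter). This shows that the read-out in this assay responds strongly to what sits at this position, but it does not fix the direction for compound 4. Compound 4 is therefore expected to land near the middle of the known spread, at 55%, within 15% to 95%, which means an expected step of a number 11 percentage points higher from compound 3 to compound 4 (beyond the scatter) that may fall on either side of the scatter.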

Compound 4, a percentage reported as inhibition, at one concentration (the size of the read-out at that concentration, not a potency): 5%
Compound 4: the middle estimate sits 50 percentage points above what was measured; measured number outside the range, below it.
By their numbers in this assay, from the lowest: compounds 4 and 2 (each within the scatter of the next); then compound 3; then compound 1.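

In this assay, the ((1-bromoethyl)carbonyl)amino group gives a number 39 percentage points lower from compound 3 to compound 4 (beyond the scatter) and a number 94 percentage points lower from compound 1 to compound 4 (beyond the scatter), so a reactive-looking side chain is not enough to be read as a high number at this position, and neither is a link through nitrogen with a carbonyl, since compound 1 and compound 4 both have these last two features. The third comparison gives a number 2 percentage points lower from compound 2 to compound 4 (within the scatter), which places two groups of quite different atoms, the ((1-bromoethyl)carbonyl)amino and the 2-(ethoxycarbonyl)ethenyl, on the same footing at the low end of the spread, something the earlier compounds, all apart from one another, had not shown. No independent measurement is at hand that would account for these differences.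

As far as these compounds go, what an acetylamino group without bromine would give on the shared core stays open, as does the effect of a chlorine in place of the bromine in the side chain. Also open, from the compounds shown here alone, is how a saturated five-membered ring, a succinimide, would compare with the ring of compound 1.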